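A few compounds are considered here, and "the series" means these few. Any claim that something is new, unique, unknown or untested is made for them only; others in the source may bear on it.

Among the measured compounds shown here, compound 3 `Cc1ccc(-c2noc(CCCCCCC(=O)Nc3ccccc3N)n2)cc1` is the only member of this set with a number in an assay on isolated protein for inhibition of histone deacetylase 8 (Homo sapiens), read by fluorescence, with a stated time of 10 min (on this read-out higher numbers stand for weaker inhibition and lower numbers for stronger inhibition), where compound 3 gives 8390 nM. Compound 2 `Nc1ccccc1NC(=O)CCCCCCc1nc(-c2ccccc2)no1` is reported in this assay only as a limit, > 10000 nM. Compound 1 `O=C(CCCCCCc1nc(-c2ccc(C(F)(F)F)cc2)no1)NO` likewise reaches only a limit in this assay, > 10000 nM. For the measured compounds named here, the single measured step, an at least 1.1-fold lower number from compound 2 to compound 3 (0.07 log units; that floor lies within the scatter), is small and rests on (the limit of > 10000 nM in this assay, at which 2 of the 3 values shown sit). Compound 4 `Nc1ccccc1NC(=O)CCCCCCc1nc(-c2ccc(C(F)(F)F)cc2)no1` carries trifluoromethyl in place of methyl on an aromatic carbon. Going by the values given here, no measured step covers this change; compound 1, which also bears the trifluoromethyl group, sits at the limit in this assay. Compound 4 is therefore expected near the limit again, estimated at 12000 nM, between 4000 nM and 40000 nM. The expected step is a 1.4-fold higher number from compound 3 to compound 4 (0.16 log units; within the scatter).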

Compound 4, half-maximal inhibitory concentration: > 10000 nM
Compound 4: only a limit was reported; the forecaster's own chance of this, stated with the estimate: 55%; the middle value lies beyond the limit too.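

Among the compounds shown here, on the aromatic carbon para to a large group, the change from 4-methylphenyl to 4-(trifluoromethyl)phenyl gives an at least 1.1-fold higher number from compound 3 to compound 4 (0.07 log units; that floor lies within the scatter), so it brings no readable gain in this assay, and compound 3 remains the only compound with a number. The steps to compound 4 from compound 2 and from compound 1 cannot be read, because each pair sits at the same limit: the limit of > 10000 nM in this assay, at which 3 of the 4 values shown sit.

On these data alone, how far compound 4 lies beyond its limit stays open. Also open, as far as these compounds go, is whether an amine or a methoxy group on this carbon, or a shorter chain, would give a clearly lower number than compound 3.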